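A cyano swap at the limit of the assay

This account rests on a few compounds, and the source may have more. Where it says the series, first, only, none or still open, it means among the compounds named here.

In a functional assay on MT4 cells (Homo sapiens) for cytotoxicity (a higher number here means a weaker inhibitor, a lower number a stronger inhibitor), compound 1 (`COc1ccc([S+]([O-])c2cccc(N)c2C#N)cc1`) gives > 200000 nM, which is a limit and not a number. Compound 2 (`N#Cc1c(N)cccc1[S+]([O-])c1ccc(Br)cc1`) gives > 200000 nM, again a limit. Compound 3 (`N#Cc1ccc([S+]([O-])c2cccc(N)c2C#N)cc1`) carries cyano in place of bromo on an aromatic carbon, para to a large group: cyano in place of bromo on an aromatic carbon. Among the measured compounds shown here, the one measured step that bears on this is a step that the two limits leave unreadable from compound 1 to compound 2, and the only evidence beside it is the limit of > 200000 nM in this assay, at which 2 of the 2 values shown sit. With no readable size to build on, no change beyond the usual scatter is expected in this assay, so the expected step is a number no higher from compound 2 to compound 3 (the limit leaves the size open). Compound 3 is estimated at 200000 nM, within a range from 100000 nM to 400000 nM.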

Compound 3, half-maximal inhibitory concentration: > 200000 nM
Compound 3 gave a limit, no number (the forecaster's own chance of this, stated with the estimate: 85%); the middle value sits exactly at the limit.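

Among the compounds shown here, compound 1, compound 2 and compound 3 each give only a limit in this assay, and no step among them can be read. On these data alone, whether any group on this aromatic carbon would give a readable number stays open.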